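Swapping One Halogen for Another on a Second Core

This account rests on a few compounds, and the source may have more. Where it says the series, first, only, none or still open, it means among the compounds named here.

Four compounds share a common design in which a benzyl group carrying a halogen is joined, through a linker, to an aromatic ether. Compound 1 has the structure `O=[N+]([O-])c1cccc(OCc2cn(Cc3ccc(Cl)cc3)nn2)c1`. In a physicochemical assay, read by spectrophotometry, with a stated time of 30 min (a lower number here means a stronger inhibitor, a higher number a weaker inhibitor), compound 1 gives 37.3 ug/mL. Compound 2, with the structure `O=[N+]([O-])c1cccc(OCc2cn(Cc3ccc(Br)cc3)nn2)c1`, differs from compound 1 in a single way: bromo in place of chloro on an aromatic carbon. In this assay compound 2 gives 29.4 ug/mL, so the step is a 1.3-fold lower number from compound 1 to compound 2 (0.10 log units; within the scatter).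

Compound 3, with the structure `Cc1cc(OCc2cn(Cc3ccc(Cl)cc3)nn2)ccc1Cl`, carries a different core; how that core differs from the core of compound 1 is not broken down here. In this assay compound 3 gives 11.4 ug/mL, the lowest of the three numbers, and its steps to compound 2 and compound 1 are both beyond the scatter.

Compound 4, with the structure `Cc1cc(OCc2cn(Cc3ccc(Br)cc3)nn2)ccc1Cl`, has not been measured. It differs from compound 3 in one place: bromo in place of chloro on an aromatic carbon. The place is the same as in the earlier change, so this is the same change, now made on the core of compound 3.

Going by the values given here, the only guide is that the earlier change gave a 1.3-fold lower number from compound 1 to compound 2 (0.10 log units; within the scatter). The expected step is therefore small, a 1.3-fold lower number from compound 3 to compound 4 (0.10 log units; within the scatter), within the scatter. On that basis, compound 4 is expected to give about 9 ug/mL in this assay, with a likely range from 4.5 ug/mL to 18 ug/mL.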

Compound 4, half-maximal inhibitory concentration: 16.5 ug/mL
For compound 4 the middle estimate is 1.8-fold (0.26 log units) below the measured one; the range from low to high includes it.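

On the core of compound 1, replacing chloro with bromo gave (a 1.3-fold lower number from compound 1 to compound 2 (0.10 log units; within the scatter)) in this assay, and on the core of compound 3 the same replacement gave (a 1.4-fold higher number from compound 3 to compound 4 (0.16 log units; within the scatter)). Both steps lie within the scatter, so on these two cores the change shifts the number by no more than repeat measurements of one compound could, and the opposite directions of the two steps cannot be read as the change acting differently on each core. Two cores are a narrow base, and this result does not show that the swap would stay this small on any other core, nor does any measurement here bear on why it is small on these two.

The compounds shown leave open how far the number would move with something other than these two halogens in the same place on the benzyl ring, such as a fluoro, an amine or a carboxylic acid. They also leave open whether the pairing of chloro and bromo would behave the same way on a third core, for example one that keeps the ether but carries a nitrile on its aromatic ring.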